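A Chloro Substituent on the Core Shared by Two Amides

A few compounds are considered here, and "the series" means these few. Any claim that something is new, unique, unknown or untested is made for them only; others in the source may bear on it.

Of the compounds shown here, two have so far been measured in an assay on membranes from striatum with 5-hydroxytryptamine receptor 4 (Rattus norvegicus) as the target; a lower number here means a stronger inhibitor, a higher number a weaker inhibitor. Compound 1 `CCN1CCC(NC(=O)c2cccc3[nH]cnc23)CC1` gives 1000 nM in this assay. Compound 2 `CS(=O)(=O)NCCN1CCC(CNC(=O)c2cccc3[nH]cnc23)CC1` gives 11.5 nM in this assay, the lower of the two numbers and well apart from the value of compound 1, which is the only other one known. Compound 3 `CS(=O)(=O)NCCN1CCC(CNC(=O)c2cc(Cl)cc3[nH]cnc23)CC1` has not yet been measured. It differs from compound 2 in one place: chloro in place of hydrogen on an aromatic carbon. Among the compounds with values here, no pair of measured compounds shows the effect of this kind of change, so there is no measured step to lean on. The expected step, a 1.4-fold lower number from compound 2 to compound 3 (0.16 log units; within the scatter), is small, either a slight gain in potency or nothing beyond the scatter. For compound 3 the estimated value in this assay is 8 nM, with an expected range from 3 nM to 25 nM.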

Compound 3, inhibition constant: 0.11 nM
The estimate for compound 3 lay 73-fold (1.86 log units) above the measured number; measured number below the stated range.
By their numbers in this assay, from the lowest: compound 3; then compound 2; then compound 1.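

Putting chloro in place of hydrogen on this aromatic carbon, meta to a large group and para to a fused ring, brings a 100-fold lower number from compound 2 to compound 3 (2.02 log units; beyond the scatter) in this assay, a step well beyond the scatter. The earlier compounds shown here both carried hydrogen at this place, so they could not show that the position responds to a substituent, or that one chlorine atom alone can shift the number this far. Nothing measured here accounts for a step of this size.

On these data alone, it remains open whether fluoro, bromo or methyl on the same carbon would give a comparable step, and whether chloro elsewhere on this ring would do so. As far as these compounds go, it is also open whether chloro at this place would lower the number for compound 1, whose side chain differs from that of compound 2.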